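The compounds below may be only part of what the source reports. "The series", "measured", "known", "first", "only" and "open" are said of these compounds alone.

Measured compounds:
Compound 1, `CC(=O)NCC[C@@H]1C[C@@H](c2ccc(F)c(F)c2)[C@H](NC(=O)c2cc(-c3c(Cl)cnn3C)c(Cl)o2)CN1`, 130 nM
Compound 2, `COCC[C@@H]1C[C@@H](c2ccc(Cl)c(Cl)c2)[C@H](NC(=O)c2cc(-c3c(Cl)cnn3C)c(Cl)o2)CN1`, 250 nM

Both compounds were tested in a functional assay on LNCaP cells (Homo sapiens) for antiproliferative activity; on this read-out lower numbers stand for stronger inhibition and higher numbers for weaker inhibition. Compound 2 stands at 250 nM, while compound 1 stands at 130 nM; the two numbers lie within the usual scatter of each other, so neither compound stands apart from the other on these data. Compound 3, `Cn1ncc(Cl)c1-c1cc(C(=O)N[C@@H]2CN[C@H](CC(O)CO)C[C@H]2c2ccc(Cl)c(Cl)c2)oc1Cl`, has not yet been tested. It differs from compound 2 in one place: 1,2-dihydroxyethyl in place of methoxymethyl on a saturated chain carbon bound to a saturated ring carbon. Within the data shown here, no pair of measured compounds differs in a single place, so nothing here shows how a change of this kind moves the numbers in this assay. A small step is expected, if any, tending toward a somewhat higher number: a 1.3-fold higher number from compound 2 to compound 3 (0.11 log units; within the scatter). Compound 3 is therefore expected to give about 320 nM, within a range from 120 nM to 850 nM.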

Compound 3, half-maximal inhibitory concentration: 70 nM
Compound 3: the middle estimate sits 4.6-fold (0.66 log units) above what was measured; measured number outside the range, below it.
By their numbers in this assay, from the lowest: compounds 3, 1 and 2 (each within the scatter of the next, the first and the last beyond it).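

In this assay, putting 1,2-dihydroxyethyl in place of methoxymethyl on a saturated chain carbon bound to a saturated ring carbon gives a 3.6-fold lower number from compound 2 to compound 3 (0.55 log units; beyond the scatter), a step beyond the usual scatter. Among these compounds, this is the first single-place comparison in the set, and it shows that the number responds to what this chain carries. The entering group has hydrogen-bond donors and the leaving group has none, but no measurement here links the step to that difference or to any other property.

The compounds shown leave open whether a single hydroxyl would give a similar number, as this one change alters both the oxygen count and the donor count. They also leave open how an amine, a carboxylic acid or a longer chain would behave at this place.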